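This account rests on a few compounds, and the source may have more. Where it says the series, first, only, none or still open, it means among the compounds named here.

Compound 1 `CCCCCCCCCC(O)C#CC#CC(O)CCC`: 30000 nM
Compound 2 `CCCC(O)C#CC#CC(O)C1CCCCC1`: > 50000 nM
Compound 3 `CCCCC[C@@H](O)C#CC#C[C@H](O)CCCCC`: 12000 nM

In a toxicity assay on Hepa-1c1c7 cells (Mus musculus) for inhibition (a lower number here means a stronger inhibitor, a higher number a weaker inhibitor), compound 1 gives 30000 nM, the highest of the two actual numbers. Compound 3 is nearest at 12000 nM, lower by a margin beyond the scatter. Compound 2 gives > 50000 nM, which is a limit and not a number.

Compound 4 `CCCCCCCCCC(O)C#CC#CC(O)CC(C)C` differs from compound 1 in one place: methyl in place of hydrogen on a saturated chain carbon bound to two saturated chain carbons. It carries methyl in place of hydrogen on a saturated chain carbon bound to two saturated chain carbons, so propyl becomes isobutyl. Within the data shown here, no measured pair shows this change, so only a small shift within the scatter is expected, with no firm direction. The expected step is a 1.2-fold lower number from compound 1 to compound 4 (0.08 log units; within the scatter). The estimate for compound 4 is 25000 nM, with an expected range of 12000 nM to 50000 nM.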

Compound 4, half-maximal inhibitory concentration: > 50000 nM
Compound 4: a limit, no number; the forecaster's own chance of this, stated with the estimate: 15%; middle value at least 2.0-fold (0.30 log units) from the limit.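

Methyl in place of hydrogen on a saturated chain carbon bound to two saturated chain carbons, turning propyl into isobutyl, gives the first measured step at this position in this assay: an at least 1.6-fold higher number from compound 1 to compound 4 (0.22 log units; that floor lies within the scatter). Compound 4 gives > 50000 nM, which is a limit and not a number. The step is therefore only a floor, and the true size of the change stays hidden at the ceiling of the assay: the limit of > 50000 nM in this assay, at which 2 of the 4 values shown sit.

The compounds shown leave open whether an amine or a carboxylic acid on the propyl of compound 1 would give a lower number in this assay.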